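Halogenated aryl variation on the shared core: working notes

A few compounds are considered here, and "the series" means these few. Any claim that something is new, unique, unknown or untested is made for them only; others in the source may bear on it.

Measured so far:
- compound 1 `CC1(C)[C@H]2CC[C@]1(C)N(Cc1cn(-c3ccc(Cl)cc3)nn1)C(=O)C2`: 70 nM in a functional assay on A549 cells (Homo sapiens) for inhibition, read by MTT assay, with a stated time of 24 h; on this read-out higher numbers stand for weaker inhibition and lower numbers for stronger inhibition
- compound 2 `CC1(C)[C@H]2CC[C@]1(C)N(Cc1cn(-c3ccc(F)cc3)nn1)C(=O)C2`: 230 nM
- compound 3 `CC1(C)[C@H]2CC[C@]1(C)N(Cc1cn(-c3ccccc3Cl)nn1)C(=O)C2`: 70 nM

Compound 3 stands level with compound 1 at the digits recorded, and together they give the lowest numbers of the three; its nearest neighbour is compound 1, with no change at the digits printed from compound 1 to compound 3 (within the scatter), and its furthest is compound 2, with a 3.3-fold lower number from compound 2 to compound 3 (0.52 log units; beyond the scatter).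

Compound 4 `CC1(C)[C@H]2CC[C@]1(C)N(Cc1cn(-c3cccc(F)c3)nn1)C(=O)C2` has not yet been measured. It differs from compound 3 as follows: 3-fluorophenyl in place of 2-chlorophenyl on an aromatic nitrogen.

Within the data shown here, two measured steps bear on this. Fluoro in place of chloro on an aromatic carbon gave a 3.3-fold higher number from compound 1 to compound 2 (0.52 log units; beyond the scatter), a modest rise beyond the scatter. Moving the chloro group from the 4-chlorophenyl to the 2-chlorophenyl arrangement gave no change at the digits printed from compound 1 to compound 3 (within the scatter), so the position of the halogen did not register for chloro. The fluoro-for-chloro swap is therefore expected to dominate, and a modest rise in the number, a 2.9-fold higher number from compound 3 to compound 4 (0.46 log units; beyond the scatter), is expected. Compound 4 is estimated at 200 nM, within 80 nM to 500 nM.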

Compound 4, half-maximal inhibitory concentration: 180 nM
Compound 4: middle estimate off by 1.1-fold (0.05 log units), on the high side, within the range that was stated.
By their numbers in this assay, from the lowest: compounds 1 and 3 (each within the scatter of the next); then compounds 4 and 2 (each within the scatter of the next).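

In this assay, among these compounds, 3-fluorophenyl in place of 4-fluorophenyl gives a 1.3-fold lower number from compound 2 to compound 4 (0.11 log units; within the scatter), so the halogen's position does not register for fluoro either, a reading the earlier compounds offered for chloro only. The chloro compounds remain apart from the 3-fluorophenyl compound, with a 2.6-fold higher number from compound 3 to compound 4 (0.41 log units; beyond the scatter) and a 2.6-fold higher number from compound 1 to compound 4 (0.41 log units; beyond the scatter), so across these four compounds the identity of the halogen separates the numbers while its position does not, and none of the four goes against this. Nothing measured here accounts for the gap between fluoro and chloro.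

From the compounds shown here alone, whether the pattern extends to 2-fluorophenyl or 3-chlorophenyl remains open. Also open, going by these compounds, is what bromo, methoxy, an amine or a carboxylic acid on the phenyl ring would give in this assay.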